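The source may hold more compounds than are shown below. What is called first, only, known or untested is meant among the compounds shown, and "the series" means these compounds.

Compound 1 `S=C(N/N=C\c1ccnc2ccccc12)Nc1cccnc1` gives 1100 nM
Compound 2 `Fc1ccc(NC(=S)N/N=C\c2ccnc3ccccc23)cc1` gives 1070 nM
Compound 3 `S=C(N/N=C\c1ccnc2ccccc12)Nc1cccc2ccccc12` gives 1210 nM

In a functional assay on T47D cells (Homo sapiens) for cytotoxicity, read by MTT assay, with a stated time of 48 h (on this read-out lower numbers stand for stronger inhibition and higher numbers for weaker inhibition), compound 2 stands level with compound 1 and compound 3, since the three values lie within the scatter of one another. Compound 4 `S=C(N/N=C\c1ccnc2ccccc12)Nc1ccc(Br)cc1` departs from compound 2 by bromo in place of fluoro on an aromatic carbon. For the measured compounds named here, no measured step makes this exact change. The nearest evidence is a 1.0-fold lower number from compound 1 to compound 2 (0.01 log units; within the scatter), a step that swaps a whole group at the same end of the molecule and still stays within the scatter. No step beyond the scatter is therefore expected, and the expected change is a 1.1-fold lower number from compound 2 to compound 4 (0.03 log units; within the scatter). For compound 4 the estimated value is 1000 nM, with an expected range of 550 nM to 1800 nM.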

Compound 4, half-maximal inhibitory concentration: 1480 nM
Beside the measured number, compound 4's estimate is 1.5-fold (0.17 log units) below it; the measured number falls inside the stated range.
By their numbers in this assay, from the lowest: compounds 2, 1, 3 and 4 (each within the scatter of the next).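

In this assay bromo in place of fluoro on the aromatic carbon gives a 1.4-fold higher number from compound 2 to compound 4 (0.14 log units; within the scatter) and so leaves the value level. Replacing pyridin-3-yl with 4-bromophenyl likewise gives a 1.3-fold higher number from compound 1 to compound 4 (0.13 log units; within the scatter) and shows that this larger halogen, like fluoro before it, stays level with the pyridin-3-yl compound. Nothing shown offers an explanation for these level values. The compounds shown leave open whether an amine, a carboxylic acid or a longer chain at this place would also stay level with compound 2. They also leave open whether any change at this end of the molecule gives a step beyond the scatter.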